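Pyrimidinyl urea replaces tolyl urea on a shared core

The source may hold more compounds than are shown below. What is called first, only, known or untested is meant among the compounds shown, and "the series" means these compounds.

Compound 1 `CC(C)CN(CC(C)C)c1ccc(/C(=N/O)Nc2ccc(F)c(Br)c2)cc1NC(=O)NC1CCCCC1`: in an assay on HeLa cells for inhibition of Indoleamine 2,3-dioxygenase 1 (Homo sapiens) (on this read-out lower numbers stand for stronger inhibition and higher numbers for weaker inhibition), compound 1 gives 1340 nM.
Compound 2 `CC(C)CN(CC(C)C)c1ccc(/C(=N/O)Nc2ccc(F)c(Br)c2)cc1NC(=O)Nc1ccc(Cl)cc1`: compound 2 gives 440 nM.
Compound 3 `Cc1ccc(NC(=O)Nc2cc(/C(=N/O)Nc3ccc(F)c(Br)c3)ccc2N(CC(C)C)CC(C)C)cc1`: compound 3 gives 760 nM.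

Compound 3 stands second highest of the three numbers, and both neighbours lie close to it: a 1.7-fold higher number from compound 2 to compound 3 (0.24 log units; within the scatter), and a 1.8-fold lower number from compound 1 to compound 3 (0.25 log units; within the scatter). Among the compounds with values here, the only step among the three that reaches beyond the scatter is a 3.0-fold lower number from compound 1 to compound 2 (0.48 log units; beyond the scatter), which is modest.

Compound 4 `CC(C)CN(CC(C)C)c1ccc(/C(=N/O)Nc2ccc(F)c(Br)c2)cc1NC(=O)Nc1cncnc1` differs from compound 3 in one place: pyrimidin-5-yl in place of 4-methylphenyl on an amide-type nitrogen. Within the data shown here, two measured steps bear on that amide-type nitrogen, a 1.8-fold lower number from compound 1 to compound 3 (0.25 log units; within the scatter) and a 3.0-fold lower number from compound 1 to compound 2 (0.48 log units; beyond the scatter), and one alters the ring that sits on it, a 1.7-fold higher number from compound 2 to compound 3 (0.24 log units; within the scatter). Among the measured compounds shown here, none of them places a heteroaromatic ring there, so the measured compounds offer no direct precedent. The two aryl ureas, compound 2 and compound 3, lie within the scatter of each other, while the cyclohexyl urea of compound 1 gives the highest number. On that basis the step expected for compound 4 in this assay is small, likely within the scatter, with a lean toward a higher number: an estimated 1.3-fold higher number from compound 3 to compound 4 (0.10 log units; within the scatter).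

Compound 4 is therefore expected to give about 950 nM, with a range from 350 nM to 2600 nM.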

Compound 4, half-maximal inhibitory concentration: 860 nM
Compound 4: middle estimate off by 1.1-fold (0.04 log units), on the high side, within the range that was stated.
By their numbers in this assay, from the lowest: compounds 2, 3, 4 and 1 (each within the scatter of the next, the first and the last beyond it).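

On the amide-type nitrogen, a six-membered aromatic ring with 2 hetero atoms and 2 hydrogen-bond acceptors takes the place of an all-carbon ring with 0 acceptors, and in this assay the number stays within the scatter, with a 1.1-fold higher number from compound 3 to compound 4 (0.05 log units; within the scatter). The same holds against the other two groups at this position, with a 2.0-fold higher number from compound 2 to compound 4 (0.29 log units; within the scatter) for 4-chlorophenyl and a 1.6-fold lower number from compound 1 to compound 4 (0.19 log units; within the scatter) for cyclohexyl, so compound 4 cannot be told apart from any of the three, even though a 3.0-fold lower number from compound 1 to compound 2 (0.48 log units; beyond the scatter) separates cyclohexyl from 4-chlorophenyl beyond the scatter. Nothing given here accounts for this result.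

The compounds shown leave open whether other groups on this nitrogen, such as pyridin-3-yl, piperidin-4-yl or a phenyl ring bearing a carboxylic acid, would stay within the same span of numbers. They also leave open whether pyrimidin-5-yl would behave the same way if the 3-bromo-4-fluorophenyl group or the two isobutyl chains of the shared core were replaced, for example by a plain phenyl ring or by ethyl chains.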